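A few compounds are considered here, and "the series" means these few. Any claim that something is new, unique, unknown or untested is made for them only; others in the source may bear on it.

Values in a functional assay on KB cells (Homo sapiens) for antiproliferative activity, read by sulforhodamine B assay, with a stated time of 3 days; on this read-out lower numbers stand for stronger inhibition of growth and higher numbers for weaker inhibition of growth:
- compound 1 `COc1ccc(NC(=O)c2cccc(Nc3ncc(F)c(Nc4ccc(F)cc4)n3)c2)cc1`: > 10000 nM, a limit of the assay
- compound 2 `CN(C)CC(=O)Nc1cccc(Nc2ncc(F)c(Nc3ccc(F)cc3)n2)c1`: 1260 nM

Compound 1 gives no number and sits at the limit of > 10000 nM in this assay, at which 1 of the 2 values shown sits. Compound 3 `COc1cc(NC(=O)c2cccc(Nc3ncc(F)c(Nc4ccc(F)cc4)n3)c2)cc(OC)c1`, not yet measured, carries 3,5-dimethoxyphenyl in place of 4-methoxyphenyl on an amide-type nitrogen. Among the measured compounds shown here, the only measured step, an at least 7.9-fold lower number from compound 1 to compound 2 (0.89 log units; beyond the scatter), replaces the whole (4-methoxyphenyl)carbamoyl group, so it bears only loosely on this smaller exchange. No step beyond the scatter is therefore expected in this assay. The expected change is a number no higher from compound 1 to compound 3 (the limit leaves the size open). For compound 3 the estimate is 10000 nM (range 3000 nM to 30000 nM), and a report as a limit only is quite possible.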

Compound 3, concentration for 50% growth inhibition: 15500 nM
Estimate against measurement, compound 3: 1.6-fold (0.19 log units) below; the range from low to high includes it.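

No step can be read from compound 1 to compound 3 in this assay, because the value of compound 1 is a limit and not a number: the limit of > 10000 nM in this assay, at which 1 of the 3 values shown sits.

As far as these compounds go, whether 3,5-dimethoxyphenyl in place of 4-methoxyphenyl on an amide-type nitrogen shifts the number in this assay at all, and in which direction, stays open.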